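The source may hold more compounds than are shown below. What is called first, only, known or untested is meant among the compounds shown, and "the series" means these compounds.

Measured so far in an ADME assay on Vero cells (Chlorocebus sabaeus) for cytotoxicity, read by resazurin assay, with a stated time of 72 h; a lower number here means a stronger inhibitor, a higher number a weaker inhibitor (all three share one core and the 4-bromophenyl group):

- Compound 1 `O=C(CCN1CCN(c2ccc(F)cc2)CC1)c1ccc(Br)cc1` gives 99500 nM
- Compound 2 `O=C(CCN1CCN(c2ccc(C(F)(F)F)cc2)CC1)c1ccc(Br)cc1` gives 78800 nM
- Compound 3 `O=C(CCN1CCN(c2ccc([N+](=O)[O-])cc2)CC1)c1ccc(Br)cc1` gives 79800 nM

Compound 3 cannot be told apart from the other two compounds. The comparisons a 1.0-fold higher number from compound 2 to compound 3 (0.01 log units; within the scatter) and a 1.2-fold lower number from compound 1 to compound 3 (0.10 log units; within the scatter) both stay within the normal spread of repeated measurements.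

The next compound is compound 4 `O=C(CCN1CCN(c2ccc([N+](=O)[O-])cc2)CC1)c1ccc(Cl)c(F)c1`, and the structural change is 4-chloro-3-fluorophenyl in place of 4-bromophenyl on a carbonyl carbon. In words, this places 4-chloro-3-fluorophenyl in place of 4-bromophenyl on a carbonyl carbon. Among the measured compounds shown here, no measured compound varies this group, so the data offer no direct guide to this change.

For the measured compounds named here, the only evidence is indirect. The measured steps exchange fluoro, trifluoromethyl and nitro on an aromatic carbon while 4-bromophenyl stays fixed. Besides the two comparisons above, a 1.3-fold lower number from compound 1 to compound 2 (0.10 log units; within the scatter) is the third such step, and none of the three moves the number beyond the scatter. On this thin basis, no shift beyond the scatter is expected in this assay, and neither direction is favoured.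

The expected change is a 1.0-fold higher number from compound 3 to compound 4 (0.00 log units; within the scatter).

The estimated value for compound 4 is 80000 nM, with an expected range of 40000 nM to 150000 nM.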

Compound 4, half-maximal inhibitory concentration: 89200 nM
Compound 4: middle estimate off by 1.1-fold (0.05 log units), on the low side; low and high end bracket the measured number.
By their numbers in this assay, from the lowest: compounds 2, 3, 4 and 1 (each within the scatter of the next).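

In this assay, among the compounds shown here, the first change at the group on the carbonyl carbon, 4-chloro-3-fluorophenyl in place of 4-bromophenyl, gives a 1.1-fold higher number from compound 3 to compound 4 (0.05 log units; within the scatter) and so stays inside the normal spread of repeat measurements. For the compounds shown here, until now only the aromatic group at the far end of the shared core had been varied, so this is the first sign that this second site can also take a different halogen-bearing phenyl group without a readable shift in this assay, at least with the nitro group in place. Nothing measured here explains this outcome or says what the new group does in the cells.

From the compounds shown here alone, the result covers a single exchange in which both groups are halogen-bearing phenyl rings, so it remains open whether an amine or a carboxylic acid on that ring, or a longer saturated chain on the carbonyl carbon, would move the number beyond the scatter. Going by these compounds, it is also open whether 4-chloro-3-fluorophenyl would behave the same way in compounds carrying fluoro or trifluoromethyl instead of nitro.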